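The source may report more compounds than this note shows. Statements on the series, on what has been measured and on what is new or still open speak of the compounds shown alone.

Among the compounds with values here, compound 1, with structure `CC/C=C/C/C=C\C[C@@]1(O)C=C(Cl)C(=O)/C1=C/[C@H](OC(C)=O)[C@H](CCCC(=O)OC)OC(C)=O`, is one of two compounds measured in a functional assay on cells (HCT cell line, Homo sapiens) for cytotoxicity; on this read-out lower numbers stand for an effect already at smaller amounts and higher numbers for an effect only at larger amounts of compound. In this assay compound 1 gives 320 nM, the highest of the two numbers recorded. Within the data shown here, the other compound, compound 2 with structure `CCCCC/C=C\C[C@@]1(O)C=C(Cl)C(=O)/C1=C\[C@H](C(C)=O)[C@H](CCCC(=O)OC)OC(C)=O`, gives 32 nM in this assay; the gap between the two values lies beyond the scatter, but compound 2 differs from compound 1 in more than one place, so the two values alone show only that compound 2 sits at the lower number. Compound 3, with structure `CCCCC/C=C\C[C@@]1(O)C=C(Cl)C(=O)/C1=C/[C@H](OC(C)=O)[C@H](CCCC(=O)OC)OC(C)=O`, has not yet been measured in this assay. It differs from compound 1 in a single place: butyl in place of but-1-en-1-yl on a saturated chain carbon bound to a double-bonded chain carbon. Compound 3 thus carries the same saturated chain as compound 2 while keeping the rest of compound 1. Among the measured compounds shown here, no single-change step between measured compounds is available, so the direction has to be inferred from compound 2, whose value of 32 nM lies at the lower end. Compound 3 is therefore expected to shift toward a lower number, with the step of a 2.0-fold lower number from compound 1 to compound 3 (0.30 log units; within the scatter) expected to be modest and possibly within the scatter. The estimate for compound 3 is 160 nM, with a range from 50 nM to 500 nM.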

Compound 3, half-maximal effective concentration: 330 nM
Compound 3: middle estimate off by 2.1-fold (0.31 log units), on the low side; low and high end bracket the measured number.
By their numbers in this assay, from the lowest: compound 2; then compounds 1 and 3 (each within the scatter of the next).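

In this assay, the direct reading at this position is a 1.0-fold higher number from compound 1 to compound 3 (0.01 log units; within the scatter), so on the core of compound 1 this read-out does not separate but-1-en-1-yl from butyl on a saturated chain carbon bound to a double-bonded chain carbon. Compound 3 shares its saturated chain with compound 2, yet compound 2 stands at the lower number, 32 nM. The compounds shown do not settle which of the other differences between compound 2 and compound 3 goes with it. No measurement at hand offers an explanation for this result.

The compounds shown leave open whether the same holds on the core of compound 2, where the saturated chain and the double bond in the unsaturated chain could read differently from how they read on the core of compound 1. They also leave open how this position would respond to a group of another kind, such as a longer chain like octyl, or a chain ending in an amine or a carboxylic acid.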